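The compounds below may be only part of what the source reports. "The series", "measured", "known", "first", "only" and "open" are said of these compounds alone.

Working notes on the series around compound 3.

Three compounds have numbers in a functional assay on CHO cells for antagonist activity at prostaglandin E2 receptor EP3 subtype (Homo sapiens), read by cAMP accumulation; on this read-out lower numbers stand for stronger inhibition and higher numbers for weaker inhibition. Compound 1 `CCn1ncc2c(F)cc(-c3ccc(C(CC)(CC)c4nncn4C)c(=O)[nH]3)cc21` gives 120 nM in this assay. Compound 2 `CC(C)C(c1cnc(N)s1)c1ccc(-c2ccc3cccc(F)c3c2)[nH]c1=O` gives 39 nM in this assay. Compound 3 `CC(C)C(Cc1noc(=O)[nH]1)c1ccc(-c2ccc3cccc(F)c3c2)[nH]c1=O` gives 70 nM in this assay. Compound 3 therefore has the second highest of the three numbers; its nearest neighbour is compound 1 and its furthest is compound 2, and both of those gaps are within the scatter, so no order among the three can be claimed.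

The next compound, compound 4 `CC(C)C(/C=C1\CCNC1=O)c1ccc(-c2ccc3cccc(F)c3c2)[nH]c1=O`, differs from compound 3 in one place: a group of 7 heavy atoms (5 carbon, 1 nitrogen, 1 oxygen; one five-membered non-aromatic ring with 1 hetero atom) in place of a group of 7 heavy atoms (3 carbon, 2 nitrogen, 2 oxygen; one five-membered aromatic ring with 3 hetero atoms), on a saturated chain carbon bound to an aromatic carbon and a saturated chain carbon

For the measured compounds named here, only one measured step bears on this position. It is a 1.8-fold higher number from compound 2 to compound 3 (0.25 log units; within the scatter), an exchange of one five-membered aromatic ring for another on the same saturated chain carbon, and it stayed within the scatter. Going by the values given here, the change to compound 4 puts a five-membered non-aromatic ring with 1 hetero atom there instead; no measured step shows such a group. Among the compounds with values here, on the one step available, the expected step of a 1.3-fold higher number from compound 3 to compound 4 (0.11 log units; within the scatter) is none beyond the scatter, with the range widened because the entering group is new to the series. Compound 4 is expected to give about 90 nM in this assay, within 30 nM to 270 nM.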

Compound 4, half-maximal inhibitory concentration: 8.7 nM
Compound 4: middle estimate off by 10-fold (1.01 log units), on the high side; measured number below the stated range.
By their numbers in this assay, from the lowest: compound 4; then compounds 2, 3 and 1 (each within the scatter of the next, the first and the last beyond it).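

This position now shows a step beyond the scatter: in this assay the five-membered non-aromatic ring with 1 hetero atom gives an 8.0-fold lower number from compound 3 to compound 4 (0.91 log units; beyond the scatter) and a 4.5-fold lower number from compound 2 to compound 4 (0.65 log units; beyond the scatter), whereas the exchange between the two aromatic rings stayed within the scatter at a 1.8-fold higher number from compound 2 to compound 3 (0.25 log units; within the scatter). The group on this saturated chain carbon is therefore not freely exchangeable, and the matching count of 7 heavy atoms in the leaving and entering groups of compounds 3 and 4 did not keep their numbers together. No measurement available here accounts for this step.

The compounds shown leave open how a carboxylic acid, an amine or a longer chain would read on this saturated chain carbon. Also open, as far as these compounds go, is whether the entering group would give a similar step on the core of compound 1.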